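Ether chain shortening in a pair of inactive ketoesters

The source may report more compounds than this note shows. Statements on the series, on what has been measured and on what is new or still open speak of the compounds shown alone.

Measured so far:
compound 1, `CCOC(=O)[C@@H]1C[C@@]23CN(C)C[C@@H](CCC4=C2[C@@H]1CC4=O)C31CC[C@](CC)(OC)OC1`, in a functional assay on A549 cells (Homo sapiens) for cytotoxicity, read by MTT assay, with a stated time of 48 h (a lower number here means a stronger inhibitor, a higher number a weaker inhibitor), gives > 40000 nM, a limit of the assay rather than a number.
compound 2, `CCO[C@@]1(CC)CCC2(CO1)[C@@H]1CCC3=C4[C@H](CC3=O)[C@H](C(=O)OC)C[C@@]42CN(C)C1`, in this assay gives > 40000 nM, likewise a limit of the assay rather than a number.

Compound 2 therefore stands at no measurable position; both measured compounds sit together at the limit of > 40000 nM in this assay, at which 2 of the 2 values shown sit. Among the compounds with values here, no step between measured compounds can be computed, so nothing is known about how any structural change moves this read-out.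

Compound 3, `CC[C@]1(OC)CCC2(CO1)[C@@H]1CCC3=C4[C@H](CC3=O)[C@H](C(=O)OC)C[C@@]42CN(C)C1`, is the unmeasured member. It differs from compound 2 by hydrogen in place of methyl on a saturated chain carbon bound to an oxygen on a saturated carbon. This is a small trimming of the ether chain with no change in ring count or in polar atoms. Within the data shown here, with compound 2 at a limit and no measured step to draw on, the expectation is no step beyond the scatter from compound 2 to compound 3 a step that the limit leaves unreadable from compound 2 to compound 3, and compound 3 is most likely to return another limit. Compound 3 is estimated at 50000 nM, in the range 20000 nM to 150000 nM.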

Compound 3, half-maximal inhibitory concentration: > 40000 nM
Compound 3: a limit, no number (the forecaster's own chance of this, stated with the estimate: 85%); the middle value does not contradict the limit.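

The steps from compound 1 and from compound 2 to compound 3 cannot be read, as all three compounds sit at one limit of the assay: the limit of > 40000 nM in this assay, at which 3 of the 3 values shown sit.
From the compounds shown here alone, whether any change on the shared core gives a measurable value in this read-out remains open.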